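From a Fluorinated Benzyl Group to a Brominated One

The compounds below may be only part of what the source reports. "The series", "measured", "known", "first", "only" and "open" are said of these compounds alone.

Compound 1: `Cc1cc(Nc2nc(NCc3ccccc3)nc3[nH]ncc23)n[nH]1` — 1960 nM
Compound 2: `Cc1cc(Nc2nc(NCc3ccccc3F)nc3[nH]ncc23)n[nH]1` — 389 nM

In an assay on isolated protein for inhibition of serine/threonine-protein kinase PAK 4 (Homo sapiens), read by HTRF, with a stated time of 60 min (a lower number here means a stronger inhibitor, a higher number a weaker inhibitor), compound 2 gives the lowest number of the two measured, with compound 1 the only other, a 5.0-fold lower number from compound 1 to compound 2 (0.70 log units; beyond the scatter). Compound 3, `Cc1cc(Nc2nc(NCc3ccc(Br)cc3)nc3[nH]ncc23)n[nH]1`, differs from compound 2 in one place: 4-bromophenyl in place of 2-fluorophenyl on a saturated chain carbon bound to a nitrogen on an aromatic ring. Among the measured compounds shown here, the only measured step, a 5.0-fold lower number from compound 1 to compound 2 (0.70 log units; beyond the scatter), swapped hydrogen for fluoro; it bears on this change only loosely, since here a different halogen enters at a different part of the ring. Compound 3 is therefore estimated near 900 nM (range 250 nM to 3500 nM). This expected step, a 2.3-fold higher number from compound 2 to compound 3 (0.36 log units; beyond the scatter), is uncertain and may be no more than scatter.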

Compound 3, half-maximal inhibitory concentration: 1320 nM
Compound 3: middle estimate off by 1.5-fold (0.17 log units), on the low side; the range from low to high includes it.
By their numbers in this assay, from the lowest: compound 2; then compounds 3 and 1 (each within the scatter of the next).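

In this assay, the gain seen with fluoro does not carry over to every halogen on this ring: the change to 4-bromophenyl gives a 3.4-fold higher number from compound 2 to compound 3 (0.53 log units; beyond the scatter), and bromo in place of hydrogen gives only a 1.5-fold lower number from compound 1 to compound 3 (0.17 log units; within the scatter), which lies within the scatter. Compound 2 and compound 3 differ in both the halogen and its place on the ring, so these two changes cannot be separated here. No measurement at hand explains the difference. Still open, going by these compounds, is which of the two changes matters, and how a methoxy group or an amine on this ring would compare.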